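From Dichlorophenyl Urea to Trifluoromethylphenyl Urea

The compounds below may be only part of what the source reports. "The series", "measured", "known", "first", "only" and "open" are said of these compounds alone.

Three compounds share one core. Compound 1 `COc1cc(Cl)cc(-c2nn(-c3cccc(NC(=O)c4ccc(Cl)c(Cl)c4)c3)cc2-c2ccncc2)c1` carries an amide, and in a functional assay on COLO 205 cells (Homo sapiens) for inhibition, read by sulforhodamine B assay, with a stated time of 48 h, tested at 10 uM (a higher number here means a weaker effect of the compound at the concentration tested, a lower number a stronger effect), compound 1 gives 81.5%. Among the measured compounds shown here, compound 3 `COc1cc(Cl)cc(-c2nn(-c3cccc(NC(=O)Nc4ccc(Cl)c(Cl)c4)c3)cc2-c2ccncc2)c1` is the matching urea; in this assay compound 3 gives -70.3%, and the step of a number 151.8 percentage points lower from compound 1 to compound 3 (beyond the scatter) is the only measured step between neighbours. Compound 2 `COc1cc(Cl)cc(-c2nn(-c3cccc(NC(=O)Nc4cc(C(F)(F)F)cc(C(F)(F)F)c4)c3)cc2-c2ccncc2)c1`, a urea with two trifluoromethyl groups, gives -64% in this assay, within the scatter of compound 3. Of the three numbers, compound 3 has the lowest. Compound 4 `COc1cc(Cl)cc(-c2nn(-c3cccc(NC(=O)Nc4cccc(C(F)(F)F)c4)c3)cc2-c2ccncc2)c1` differs from compound 3 by 3-(trifluoromethyl)phenyl in place of 3,4-dichlorophenyl on an amide-type nitrogen. For the measured compounds named here, no measured step covers this change. Because compound 2 gives -64% with a trifluoromethyl-bearing urea, the step of a number 15.3 percentage points higher from compound 3 to compound 4 (beyond the scatter) is expected to stay within the scatter. Compound 4 is expected to give -55%, between -90% and 0%.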

Compound 4, a percentage reported as activity, at one concentration (the size of the read-out at that concentration, not a potency): -31.2%
Beside the measured number, compound 4's estimate is 23.8 percentage points below it; measured number inside the range.
By their numbers in this assay, from the lowest: compounds 3 and 2 (each within the scatter of the next); then compound 4; then compound 1.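

At the amide-type nitrogen, the choice of urea aryl group matters: in this assay there is a number 39.1 percentage points higher from compound 3 to compound 4 (beyond the scatter), and replacing one trifluoromethyl with hydrogen gives a number 32.8 percentage points higher from compound 2 to compound 4 (beyond the scatter), even though compound 2 and compound 3 lie within the scatter of each other. Changing both the link and the aryl group gives a number 112.7 percentage points lower from compound 1 to compound 4 (beyond the scatter), so this step cannot be assigned to either change alone. No measurement here explains these steps. Going by these compounds, it remains open how a urea carrying a single fluorine or a methyl group on this phenyl ring would compare.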